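Replacing 2-chloro-6-methylphenyl with 3-bromophenyl

A few compounds are considered here, and "the series" means these few. Any claim that something is new, unique, unknown or untested is made for them only; others in the source may bear on it.

For the measured compounds named here, in a functional assay on MDA-MB-231 cells (Homo sapiens) for cytotoxicity, read by MTT assay, with a stated time of 72 h (on this read-out lower numbers stand for stronger inhibition and higher numbers for weaker inhibition), compound 3 (`Cc1cccc(Cl)c1NC(=O)CN1CCN(c2nnc(Cc3ccccc3)c3ccccc23)CC1`) gives 3920 nM, the lowest of the three numbers so far. Compound 2 (`O=C(CN1CCN(c2nnc(Cc3ccccc3)c3ccccc23)CC1)Nc1ccc(Br)cc1`) gives 12400 nM, and compound 1 (`COc1ccc(NC(=O)CN2CCN(c3nnc(Cc4ccccc4)c4ccccc34)CC2)cc1OC`) gives 32200 nM. Compound 4 (`O=C(CN1CCN(c2nnc(Cc3ccccc3)c3ccccc23)CC1)Nc1cccc(Br)c1`), not yet measured, carries 3-bromophenyl in place of 2-chloro-6-methylphenyl on an amide-type nitrogen. The closest guide is a 3.2-fold lower number from compound 2 to compound 3 (0.50 log units; beyond the scatter), a modest step, since compound 2 bears 4-bromophenyl. The steps of a 2.6-fold lower number from compound 1 to compound 2 (0.41 log units; beyond the scatter) and an 8.2-fold lower number from compound 1 to compound 3 (0.91 log units; beyond the scatter) are also modest and show the span of this small set. A modest rise in the number is therefore expected, towards that of compound 2. The expected step is a 2.6-fold higher number from compound 3 to compound 4 (0.41 log units; beyond the scatter). The estimate for compound 4 is 10000 nM, with an expected range of 4000 nM to 25000 nM.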

Compound 4, half-maximal inhibitory concentration: 3880 nM
The estimate for compound 4 lay 2.6-fold (0.41 log units) above the measured number, outside the stated range (below it).
By their numbers in this assay, from the lowest: compounds 4 and 3 (each within the scatter of the next); then compound 2; then compound 1.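

With the bromine on the phenyl ring, the position on the amide-type nitrogen proves sensitive to substitution pattern: 3-bromophenyl in place of 4-bromophenyl gives a 3.2-fold lower number from compound 2 to compound 4 (0.50 log units; beyond the scatter). Two differently substituted rings can also read alike, as 3-bromophenyl in place of 2-chloro-6-methylphenyl gives a 1.0-fold lower number from compound 3 to compound 4 (0.00 log units; within the scatter). The step from 3,4-dimethoxyphenyl, an 8.3-fold lower number from compound 1 to compound 4 (0.92 log units; beyond the scatter), is about as large as the one already seen for 2-chloro-6-methylphenyl. How a phenyl ring bearing an amine or a carboxylic acid in place of the bromine would read stays open, and nothing available here accounts for these differences.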